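Phosphorus Configuration Versus a Heteroaryl Swap in Blood

The source may report more compounds than this note shows. Statements on the series, on what has been measured and on what is new or still open speak of the compounds shown alone.

Measured so far:
Compound 1 `COC(=O)CCNC(=O)[C@@H]1O[P@](=O)(OCOC(=O)c2ccnn2C)OCC1(C)C` — in an ADME assay on blood (Homo sapiens) for pharmacokinetics (on this read-out higher numbers stand for a longer-lived compound and lower numbers for a shorter-lived compound), compound 1 gives < 0.16 h, which is a limit of the assay rather than a number.
Compound 2 `COC(=O)CCNC(=O)[C@@H]1O[P@@](=O)(OCOC(=O)c2ccnn2C)OCC1(C)C` — in this assay compound 2 gives > 1 h, which is also a limit of the assay.

Compound 1 therefore sits at the short-lived end (the limit of < 0.16 h in this assay, at which 1 of the 2 values shown sits), while compound 2 sits at the long-lived end (the limit of > 1 h in this assay, at which 1 of the 2 values shown sits). Within the data shown here, the only measured step, an at least 6.2-fold higher number from compound 1 to compound 2 (0.79 log units; beyond the scatter), rests on a single change in configuration at phosphorus (the fact that compounds 1 and 2 differ only in the configuration as drawn). Compound 3 `COC(=O)CCNC(=O)[C@@H]1O[P@](=O)(OCOC(=O)c2ocnc2C)OCC1(C)C` keeps the phosphorus configuration of compound 1 and instead changes the aromatic ring on the carbonyl carbon: 4-methyl-1,3-oxazol-5-yl in place of 1-methyl-1H-pyrazol-5-yl on a carbonyl carbon. Among the measured compounds shown here, no measured step covers such an exchange of one five-membered aromatic ring for another, so nothing here argues for a shift beyond the scatter in this assay. The step that the limit leaves unreadable from compound 1 to compound 3 is expected to be small. Compound 3 is accordingly estimated at 0.12 h, within 0.05 h to 0.35 h, and is likely to be reported again only as a limit.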

Compound 3, half-life: 0.27 h
Compound 3: the middle estimate sits 2.3-fold (0.35 log units) below what was measured; the range from low to high includes it.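

In this assay, exchanging one five-membered aromatic ring for another on the carbonyl carbon gives an at least 1.6-fold higher number from compound 1 to compound 3 (0.22 log units; that floor lies within the scatter). Among these compounds, compound 3 is the first compound here with a measured number rather than a limit, so this series now has a real reading at the phosphorus configuration shared by compound 1 and compound 3. The true size of the step cannot be read, and its floor alone does not establish a change beyond the usual scatter, because compound 1 is held only as a limit: the limit of < 0.16 h in this assay, at which 1 of the 3 values shown sits.

Going by these compounds, it remains open whether the same ring exchange would shift the half-life when made on compound 2, whose phosphorus configuration is the opposite one. Also open, on these data alone, is what a phenyl ring or a short alkyl chain would give on that carbonyl carbon.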